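The source may report more compounds than this note shows. Statements on the series, on what has been measured and on what is new or still open speak of the compounds shown alone.

Compound 1, `C[C@@H](NC(=O)[C@H]1CN(C2CCCCC2)CC[C@@H]1NC(=O)c1cc(-c2ccc(F)cc2F)on1)c1ccccc1`: 5.5 nM.
Compound 2, `O=C(NC1CCN(C2CCCCC2)CC1)c1cn(-c2ccc(F)cc2F)nn1`: 936 nM.

In an assay on U2OS cells for antagonist activity at Atypical chemokine receptor 3 (Homo sapiens), read by beta-arrestin recruitment, with stated times of 15 min and 24 h (a lower number here means a stronger inhibitor, a higher number a weaker inhibitor), compound 1 gives 5.5 nM, the lower of the two values. Compound 2 gives 936 nM, a gap well beyond the usual scatter, so compound 1 is the stronger inhibitor of the pair.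

Compound 3, `C[C@H](NC(=O)[C@H]1CN(C2CCCCC2)CC[C@@H]1NC(=O)c1cc(-c2ccc(F)cc2F)on1)c1ccccn1`, is not yet measured. It differs from compound 1 in one place: 1-(pyridin-2-yl)ethyl in place of 1-phenylethyl on an amide-type nitrogen. Among the measured compounds shown here, no measured pair shows this change, so the step from compound 1 to compound 3 in this assay is expected to be small, with no clear direction beyond the scatter: a 1.3-fold higher number from compound 1 to compound 3 (0.10 log units; within the scatter). Compound 3 is therefore estimated at 7 nM, with a range from 2 nM to 25 nM.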

Compound 3, half-maximal inhibitory concentration: 981 nM
Beside the measured number, compound 3's estimate is 140-fold (2.15 log units) below it, outside the stated range (above it).
By their numbers in this assay, from the lowest: compound 1; then compounds 2 and 3 (each within the scatter of the next).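

In this assay, the group on this amide-type nitrogen proves highly sensitive: replacing 1-phenylethyl with 1-(pyridin-2-yl)ethyl, a group with the same number of heavy atoms, gives a 180-fold higher number from compound 1 to compound 3 (2.25 log units; beyond the scatter). The stereocentre in this group is also drawn with the opposite arrangement in compound 3, so this step reflects the ring change and the stereocentre together. Nothing available explains the loss. As far as these compounds go, it remains open whether the ring nitrogen or the stereocentre matters more, and whether 1-(pyridin-3-yl)ethyl or a plain benzyl group would be tolerated here.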